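Adding an Amino Group to a Chloropurine Benzyl Scaffold

The source may hold more compounds than are shown below. What is called first, only, known or untested is meant among the compounds shown, and "the series" means these compounds.

Compound 1, `ClCc1ccccc1Cn1cnc2c(Cl)nc(Cl)nc21`, gives 1540 nM in a functional assay on IGROV-1 cells (Homo sapiens) for cytotoxicity, read by sulforhodamine B assay, with a stated time of 48 h; a higher number here means a weaker inhibitor of growth, a lower number a stronger inhibitor of growth.
Compound 2, `Nc1nc(Cl)c2ncn(Cc3ccc(CCl)cc3)c2n1`, gives 9120 nM in this assay.
Compound 3, `ClCc1ccccc1Cn1cnc2c(Cl)ncnc21`, gives 3160 nM in this assay.

Compound 3 holds the second highest number of the three in this assay: compound 1 sits below it, and compound 2 sits above it. Going by the values given here, the one change that has been measured on this scaffold is a 2.1-fold higher number from compound 1 to compound 3 (0.31 log units; beyond the scatter), a modest shift that crosses the scatter.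

Compound 4, `Nc1nc(Cl)c2ncn(Cc3ccccc3CCl)c2n1`, carries a different change: amino in place of hydrogen on an aromatic carbon. Among the compounds with values here, no measured pair shows exactly this change, so the expectation rests on what the values of compound 2 and compound 3 show. Compound 2, which already bears an amino group on its core, has the highest number of the set, while compound 3 without that group sits lower. On that basis the amino group is expected to weaken growth inhibition, giving a 1.9-fold higher number from compound 3 to compound 4 (0.28 log units; within the scatter) as the estimated step. Compound 4 is therefore estimated at 6000 nM, with a range from 2500 nM to 15000 nM.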

Compound 4, concentration for 50% growth inhibition: 6310 nM
Beside the measured number, compound 4's estimate is 1.1-fold (0.02 log units) below it; low and high end bracket the measured number.
By their numbers in this assay, from the lowest: compound 1; then compounds 3, 4 and 2 (each within the scatter of the next, the first and the last beyond it).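

Amino in place of hydrogen on this carbon, between two ring nitrogen atoms, gives a 2.0-fold higher number from compound 3 to compound 4 (0.30 log units; within the scatter) in this assay, so these two groups cannot be told apart here. Amino in place of chloro on the same carbon gives a 4.1-fold higher number from compound 1 to compound 4 (0.61 log units; beyond the scatter), which, taken with the earlier hydrogen comparison, leaves chloro alone with the lower number among the three groups compared at this place. Nothing available explains why chloro stands apart from the other two.

Going by these compounds, whether a methoxy group, a dimethylamino group or a bromo group on this carbon would fall with chloro or with hydrogen and amino remains open. Also open, on these data alone, is whether chloro in place of amino on compound 2 would bring a similar step.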